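Swapping a terminal amine for a methyl ester

The source may hold more compounds than are shown below. What is called first, only, known or untested is meant among the compounds shown, and "the series" means these compounds.

compound 1 `NCCCNc1c(C(=O)NCc2ccc(F)cc2)nc(Br)c2cccnc12` gives 18000 nM
compound 2 `Nc1ccc(Nc2c(C(=O)NCc3ccc(F)cc3)nc(Br)c3cccnc23)cc1` gives 7000 nM
compound 3 `NCCNc1c(C(=O)NCc2ccc(F)cc2)nc(Br)c2cccnc12` gives > 20000 nM, a limit and not a number

These results come from a functional assay on HCT-116 cells (Homo sapiens) for cytotoxicity, read by MTT assay, with a stated time of 72 h; a higher number here means a weaker inhibitor, a lower number a stronger inhibitor. Compound 3 has no exact value, only (the limit of > 20000 nM in this assay, at which 1 of the 3 values shown sits). Compound 4 `COC(=O)CNc1c(C(=O)NCc2ccc(F)cc2)nc(Br)c2cccnc12` carries methoxycarbonyl in place of aminomethyl on a saturated chain carbon bound to a nitrogen on an aromatic ring. The nearest measured steps are an at least 1.1-fold higher number from compound 1 to compound 3 (0.04 log units; that floor lies within the scatter) and an at least 2.8-fold higher number from compound 2 to compound 3 (0.45 log units; beyond the scatter). Neither brings in methoxycarbonyl, so they offer only indirect guidance and give no reason to expect a shift beyond the scatter. The expected change is a number no higher from compound 3 to compound 4 (the limit leaves the size open). Compound 4 is estimated at 20000 nM, with an expected range from 9000 nM to 40000 nM, and it may also return only a limit.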

Compound 4, half-maximal inhibitory concentration: > 10000 nM
Compound 4: no number, only a limit; the forecaster's own chance of this, stated with the estimate: 55%; the middle value is on the limit's open side.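

Compound 4 gives > 10000 nM in this assay as a limit, not a number. Among the compounds shown here, the one readable step is an at least 1.4-fold higher number from compound 2 to compound 4 (0.15 log units; that floor lies within the scatter) and so does not set compound 4 apart from compound 2. The steps from compound 3 to compound 4 and from compound 1 to compound 4 cannot be read, so swapping aminomethyl for methoxycarbonyl has no measurable size here: the limit of > 10000 nM in this assay, at which 1 of the 4 values shown sits.

Where compound 4 lies beyond its limit stays open. Also open, from the compounds shown here alone, is what a carboxylic acid or a longer chain ending in an amine would give on this saturated chain carbon.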